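Cyclohexylamino in place of dimethylamino

The source may report more compounds than this note shows. Statements on the series, on what has been measured and on what is new or still open speak of the compounds shown alone.

Compound 1 `CCCN1C(=O)CCC1(O)c1cccc(C(F)(F)F)c1`: > 200 mg/kg
Compound 2 `CN(C)C(=O)CCC(=O)c1cccc(C(F)(F)F)c1`: > 50 mg/kg
Compound 3 `O=C(CCC(=O)c1cccc(C(F)(F)F)c1)NC1CCCCC1`: not yet measured

Both values come from a functional assay on the whole organism with Mus musculus as the target; on this read-out lower numbers stand for an effect already at smaller amounts and higher numbers for an effect only at larger amounts of compound. Compound 1 stands at > 200 mg/kg, which is a limit of the assay and not a number. Compound 2 stands at > 50 mg/kg, which is also a limit and not a number. Within the data shown here, neither compound therefore has an actual half-maximal dose, and there is no measured step to serve as a guide.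

Compound 3 keeps the rest of compound 2 and carries cyclohexylamino in place of dimethylamino on a carbonyl carbon. With so little to go on, no clear direction can be expected in this assay, and the estimated step that the limit leaves unreadable from compound 2 to compound 3 stays within the usual scatter. The assay may well report only a limit again. For compound 3 the expected value is 80 mg/kg, with an estimated range of 25 mg/kg to 250 mg/kg.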

Compound 3, dose for half-maximal effect: > 200 mg/kg
Compound 3: only a limit was reported; the forecaster's own chance of this, stated with the estimate: 55%; middle value at least 2.5-fold (0.39 log units) away from the limit.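

In this assay, among these compounds, compound 2 and compound 3 each have only a limit and not a number, so no step between them can be read. The compounds shown leave open what half-maximal dose, if any, goes with dimethylamino or with cyclohexylamino on this carbonyl carbon.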